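A few compounds are considered here, and "the series" means these few. Any claim that something is new, unique, unknown or untested is made for them only; others in the source may bear on it.

Measured in an ADME assay on HepG2 cells (Homo sapiens) for cytotoxicity; on this read-out lower numbers stand for an effect already at smaller amounts and higher numbers for an effect only at larger amounts of compound:
- compound 1 `Cc1ccc(S(=O)(=O)N[C@@H](CC(=O)NC(C)(C)C)C(=O)NCCNC(=O)c2ccc(F)cc2)cc1` gives > 11000 nM
- compound 2 `Cc1ccc(S(=O)(=O)N[C@@H](CC(=O)NC(C)(C)C)C(=O)NCCNC(=O)NCc2ccccc2)cc1` gives > 11000 nM

Both entries are limits of the assay, not numbers. Compound 2 therefore has no numerical position in the series, and the same holds for the other compound measured (the limit of > 11000 nM in this assay, at which 2 of the 2 values shown sit).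

Compound 3 `Cc1ccc(S(=O)(=O)N[C@@H](CC(=O)NC(C)(C)C)C(=O)NCCNC(=O)c2cc(C)ccc2F)cc1` carries 2-fluoro-5-methylphenyl in place of benzylamino on a carbonyl carbon.

For the measured compounds named here, the one measured step at this place is a step that the two limits leave unreadable from compound 1 to compound 2. It gives no size to carry over. Compound 1 has 4-fluorophenyl on the same carbonyl carbon and reports > 11000 nM, which is a limit. With an aromatic group directly on that carbonyl carbon, compound 3 is expected to show no step beyond the scatter in this assay, and most likely a limit again. The expected change is a step that the limit leaves unreadable from compound 2 to compound 3. For compound 3 the estimate is 14000 nM, with an expected range of 7000 nM to 30000 nM.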

Compound 3, half-maximal effective concentration: > 11000 nM
Compound 3 was reported as a limit; the forecaster's own chance of this, stated with the estimate: 85%; the middle value does not contradict the limit.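

In this assay no step can be read among compound 1, compound 2 and compound 3, since all three values are limits: the limit of > 11000 nM in this assay, at which 3 of the 3 values shown sit.

The compounds shown leave open how these three compare, and whether any group on that carbonyl carbon would give a numerical value.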